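This account rests on a few compounds, and the source may have more. Where it says the series, first, only, none or still open, it means among the compounds named here.

Compound 1 `Cc1ccccc1S(=O)(=O)NC(C1=CC(=O)c2c(O)ccc(O)c2C1=O)C(C)C`: 790 nM
Compound 2 `Cc1ccccc1S(=O)(=O)NC(C)C1=CC(=O)c2c(O)ccc(O)c2C1=O`: 4490 nM

In a functional assay on HeLa cells (Homo sapiens) for cytotoxicity, read by sulforhodamine B assay (a higher number here means a weaker inhibitor, a lower number a stronger inhibitor), compound 2 gives 4490 nM, the higher of the two numbers and so the weaker inhibitor of the pair. Compound 3 `CC(NS(=O)(=O)c1ccc(Br)cc1)C1=CC(=O)c2c(O)ccc(O)c2C1=O` has 4-bromophenyl in place of 2-methylphenyl on a sulfonyl sulfur. Within the data shown here, the only measured step, a 5.7-fold higher number from compound 1 to compound 2 (0.75 log units; beyond the scatter), changed the chain instead, so it shows only how far one swap can move the number. No measurement covers this swap, so no direction can be read and no step beyond the scatter is expected. The expected step is a 1.3-fold lower number from compound 2 to compound 3 (0.11 log units; within the scatter). For compound 3 the estimate is 3500 nM, with an expected range of 1200 nM to 10000 nM.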

Compound 3, half-maximal inhibitory concentration: 5210 nM
Estimate against measurement, compound 3: 1.5-fold (0.17 log units) below; the range from low to high includes it.
By their numbers in this assay, from the lowest: compound 1; then compounds 2 and 3 (each within the scatter of the next).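

In this assay, changing the group on the sulfonyl sulfur stays within the usual scatter (a 1.2-fold higher number from compound 2 to compound 3 (0.06 log units; within the scatter)). So this position, unlike the chain position, has so far shown no measurable effect from a swap, though this is only one swap, made with methyl on the chain. No measurement here accounts for this result. As far as these compounds go, it remains open whether 4-bromophenyl would do the same alongside the isopropyl of compound 1, and what an amine or a carboxylic acid on the aromatic ring would do.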